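The compounds below may be only part of what the source reports. "The series", "measured", "known", "first", "only" and "open" are said of these compounds alone.

Compound 1 `CS(=O)(=O)Nc1ccc2c(c1)S(=O)(=O)C=C(c1c(O)c3ccc(F)cc3n(Cc3ccc(F)cc3)c1=O)N2`: > 50000 nM
Compound 2 `CS(=O)(=O)Nc1ccc2c(c1)S(=O)(=O)C=C(c1c(O)c3cc(F)ccc3n(Cc3ccccn3)c1=O)N2`: > 50000 nM

Both compounds were tested in an ADME assay on 2209-23 cells (Homo sapiens) for cytotoxicity, read by WST assay; a higher number here means that more compound is tolerated, a lower number that less compound is tolerated. Compound 2 gives > 50000 nM, which is a limit of the assay and not a number. Compound 1 gives > 50000 nM, which is also a limit. Compound 2 therefore has no exact position on the scale, and the data show (the limit of > 50000 nM in this assay, at which 2 of the 2 values shown sit).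

Compound 3 `COC(C)(C)CCn1c(=O)c(C2=CS(=O)(=O)c3cc(NS(C)(=O)=O)ccc3N2)c(O)c2cc(F)ccc21` keeps the shared core of compound 2 and changes one substituent. It has 2-methoxy-2-methylpropyl in place of pyridin-2-yl on a saturated chain carbon bound to an aromatic nitrogen. Cut one bond further out, the same difference reads (pyridin-2-yl)methyl to 3-methoxy-3-methylbutyl.

For the measured compounds named here, no measured step between two compounds is available to size this change. The expectation rests only on the limit for compound 2, > 50000 nM. No step beyond the scatter is expected in this assay, and no direction is favoured. The estimated step is a number no higher from compound 2 to compound 3 (the limit leaves the size open). For compound 3 the estimate is 50000 nM. The estimated range runs from 25000 nM to 100000 nM.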

Compound 3, half-maximal cytotoxic concentration: > 50000 nM
Compound 3 was reported as a limit; the forecaster's own chance of this, stated with the estimate: 80%; the middle value lies on the limit itself.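

In this assay compound 3 gives > 50000 nM, which is a limit of the assay and not a number. Compound 2 also stands at a limit, so no step from compound 2 to compound 3 can be read: the limit of > 50000 nM in this assay, at which 3 of the 3 values shown sit.

The compounds shown leave open the actual half-maximal cytotoxic concentration of compound 1, compound 2 and compound 3, and whether the change of substituent alters it.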